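A smaller piperazine group on compound 2

A few compounds are considered here, and "the series" means these few. Any claim that something is new, unique, unknown or untested is made for them only; others in the source may bear on it.

In a toxicity assay on L02 cells (Homo sapiens) for cytotoxicity, read by MTT assay, with a stated time of 72 h (a higher number here means a weaker inhibitor, a lower number a stronger inhibitor), compound 1 `O=C1c2c[n+]([O-])c3ccccc3c2C(=O)c2c1c1ccccc1n2Cc1cn(CC(O)CO)nn1` gives 1070 nM while compound 2 `CCCCN1CCN(CCCCn2c3c(c4ccccc42)C(=O)c2c[n+]([O-])c4ccccc4c2C3=O)CC1` gives 5690 nM and so holds the higher of the two numbers, a gap beyond the usual scatter. Compound 3 `CN1CCN(CCCn2c3c(c4ccccc42)C(=O)c2c[n+]([O-])c4ccccc4c2C3=O)CC1` keeps the core of compound 2 and differs from it in one place. The change 4-methylpiperazin-1-yl in place of (4-butylpiperazin-1-yl)methyl on a saturated chain carbon, three bonds along the chain from an aromatic nitrogen puts 4-methylpiperazin-1-yl in place of (4-butylpiperazin-1-yl)methyl on a saturated chain carbon, three bonds along the chain from an aromatic nitrogen. Among the measured compounds shown here, no measured step speaks to this change, so the expectation starts from compound 2 at 5690 nM and allows only a modest move toward a lower number in this assay for now. The estimated step of a 1.6-fold lower number from compound 2 to compound 3 (0.21 log units; within the scatter) is expected to stay within the scatter. Compound 3 is expected at 3500 nM with 1200 nM to 10000 nM as its estimated range.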

Compound 3, half-maximal inhibitory concentration: 230 nM
Compound 3: the middle estimate sits 15-fold (1.18 log units) above what was measured, outside the stated range (below it).
By their numbers in this assay, from the lowest: compound 3; then compound 1; then compound 2.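

In this assay, putting 4-methylpiperazin-1-yl in place of (4-butylpiperazin-1-yl)methyl on a saturated chain carbon, three bonds along the chain from an aromatic nitrogen, gives a 25-fold lower number from compound 2 to compound 3 (1.39 log units; beyond the scatter) in one step, so this position responds strongly even though the piperazine ring stays. The 2-(4-methylpiperazin-1-yl)ethyl group also differs from the 1-(2,3-dihydroxypropyl)-1H-1,2,3-triazol-4-yl group, with a 4.7-fold lower number from compound 1 to compound 3 (0.67 log units; beyond the scatter), so a piperazine here can lie on either side of compound 1: compound 2 sits higher and compound 3 lower. No measurement offered here accounts for the size of these steps.

The change shortens the chain and swaps butyl for methyl together, so the compounds shown do not separate the two. From the compounds shown here alone, a longer chain carrying 4-methylpiperazin-1-yl, or a morpholine in place of the piperazine, would address what remains open.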